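Swapping the amide tail for propanoylamino

The source may hold more compounds than are shown below. What is called first, only, known or untested is meant among the compounds shown, and "the series" means these compounds.

compound 1 `C#CCNC(=O)c1cccc2c1cc(C)n2-c1nc2c(c(NCc3ccccc3)n1)CCCC2` gives 470 nM
compound 2 `Cc1cc2c(C(=O)NCC#N)cccc2n1-c1nc2c(c(NCc3ccccc3)n1)CCCC2` gives 468 nM
compound 3 `Cc1cc2c(C(=O)NCCC#N)cccc2n1-c1nc2c(c(NCc3ccccc3)n1)CCCC2` gives 517 nM

In a functional assay on MIA PaCa-2 cells (Homo sapiens) for antiproliferative activity (on this read-out lower numbers stand for an effect already at smaller amounts and higher numbers for an effect only at larger amounts of compound), compound 3 sits level with the other two (a 1.1-fold higher number from compound 1 to compound 3 (0.04 log units; within the scatter)) and (a 1.1-fold higher number from compound 2 to compound 3 (0.04 log units; within the scatter)). Compound 4 (`CCC(=O)Nc1cccc2c1cc(C)n2-c1nc2c(c(NCc3ccccc3)n1)CCCC2`) carries propanoylamino in place of (2-cyanoethyl)carbamoyl on an aromatic carbon. The measured steps, including (a 1.0-fold lower number from compound 1 to compound 2 (0.00 log units; within the scatter)), only swapped the end of the chain on the amide-type nitrogen, and all stayed within the scatter. None of them tests a swap of the whole group at the aromatic carbon, so they offer only weak guidance. In this assay no step beyond the scatter is expected, though with wide uncertainty. The expected step is small (a 1.1-fold higher number from compound 3 to compound 4 (0.03 log units; within the scatter)). Compound 4 is estimated at 550 nM (expected range 180 nM to 1600 nM).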

Compound 4, half-maximal effective concentration: 1010 nM
Estimate against measurement, compound 4: 1.8-fold (0.26 log units) below; the range from low to high includes it.
By their numbers in this assay, from the lowest: compounds 2, 1, 3 and 4 (each within the scatter of the next, the first and the last beyond it).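

Unlike the earlier steps, which changed only the end of the chain on the amide-type nitrogen, this change replaces the whole group on the aromatic carbon; in this assay it gives a 2.0-fold higher number from compound 3 to compound 4 (0.29 log units; within the scatter) and stays within the scatter. Against the other two amides, a 2.2-fold higher number from compound 2 to compound 4 (0.33 log units; beyond the scatter) and a 2.1-fold higher number from compound 1 to compound 4 (0.33 log units; beyond the scatter) both go modestly beyond the scatter, so propanoylamino needs somewhat larger amounts than those two groups. Nothing available explains this difference. Going by these compounds, whether an amine or a carboxylic acid on this aromatic carbon would change the number stays open.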